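The source may hold more compounds than are shown below. What is called first, only, known or untested is meant among the compounds shown, and "the series" means these compounds.

Compound 1 `C[C@@H](NC(=O)Nc1ccccc1C(C)(C)C)c1ccccc1` gives 17% in an ADME assay on the whole organism with Oryza sativa as the target, tested at 10 uM (a lower number here means a stronger effect, a higher number a weaker effect of the compound at the concentration tested), while compound 2 `C[C@H](NC(=O)Nc1ccccc1C(C)(C)C)c1ccccc1` gives 100% and compound 3 `C[C@@H](NC(=O)Nc1ccc(F)cc1)c1ccccc1` gives 92%. For the measured compounds named here, the only measured step runs a number 83 percentage points higher from compound 1 to compound 2 (beyond the scatter), and its size can be set against (the fact that compounds 1 and 2 differ only in the configuration as drawn). Compound 2 stands highest of the three numbers shown, with compound 3 within the scatter of it and compound 1 far below. Compound 4 `C[C@H](NC(=O)Nc1ccccc1I)c1ccccc1` differs from compound 2 by iodo in place of tert-butyl on an aromatic carbon. Going by the values given here, no measured step exchanges one group for another on this ring, so none bears directly on this change; the one step measured concerns configuration alone. Compound 4 is therefore expected to sit near compound 2, with a step of a number 15 percentage points lower from compound 2 to compound 4 (beyond the scatter) estimated in this assay. The estimate for compound 4 is 85%, between 55% and 100%.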

Compound 4, a percentage reported as activity, at one concentration (the size of the read-out at that concentration, not a potency): 98%
For compound 4 the middle estimate is 13 percentage points below the measured one; measured number inside the range.
By their numbers in this assay, from the lowest: compound 1; then compounds 3, 4 and 2 (each within the scatter of the next).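

In this assay the exchange of tert-butyl for iodo on an aromatic carbon gives a number 2 percentage points lower from compound 2 to compound 4 (within the scatter) and so is the first exchange of groups at this position among the compounds shown. With the configuration of compound 2, the two groups cannot be told apart here by this read-out. Nothing given here bears on why the number holds under this exchange. From the compounds shown here alone, it stays open whether iodo would leave the number equally unmoved in the other configuration, that of compound 1 with 17% as its number. Going by these compounds, it also stays open whether an amine or a carboxylic acid on this aromatic carbon would shift the number.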